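The source may report more compounds than this note shows. Statements on the series, on what has been measured and on what is new or still open speak of the compounds shown alone.

Compound 1 `COc1ccc2c(O[C@H]3C[C@H]4C(=O)N(C)CCCC/C=C/[C@@H]5C[C@@]5(C(=O)NS(=O)(=O)C5(C)CC5)NC(=O)N4C3)cc(-c3nc(C(F)(F)F)cs3)nc2c1C` gives 75000 nM in an ADME assay on Huh-7 cells (Homo sapiens) for cytotoxicity, read by colorimetric assay; on this read-out lower numbers stand for higher toxicity in this test and higher numbers for lower toxicity in this test.
Compound 2 `COc1ccc2c(O[C@H]3C[C@H]4C(=O)N(C)CCCC/C=C/[C@@H]5C[C@@]5(C(=O)NS(=O)(=O)C5(C)CC5)NC(=O)N4C3)cc(-c3cc(C(C)C)on3)nc2c1Cl` gives 75000 nM in this assay.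
Compound 3 `COc1ccc2c(O[C@H]3C[C@H]4C(=O)N(C)CCCC/C=C/[C@@H]5C[C@@]5(C(=O)NS(=O)(=O)C5CC5)NC(=O)N4C3)cc(-c3nc(C)cs3)nc2c1Cl` gives 75000 nM in this assay.

In this assay compound 2 stands level with compounds 1 and 3 at the digits shown. Its nearest neighbour is compound 1 and its furthest is compound 3, and in both cases the difference stays within the scatter of repeated measurements, so no order among the three can be read from these numbers. For the measured compounds named here, no pair of measured compounds differs in only one place, so there is no single-change step to lean on.

Compound 4 `C#Cc1csc(-c2cc(O[C@H]3C[C@H]4C(=O)N(C)CCCC/C=C/[C@@H]5C[C@@]5(C(=O)NS(=O)(=O)C5(C)CC5)NC(=O)N4C3)c3ccc(OC)c(Cl)c3n2)n1` differs from compound 2 in one place: 4-ethynyl-1,3-thiazol-2-yl in place of 5-isopropyl-1,2-oxazol-3-yl on an aromatic carbon. With all three measured compounds sitting at the same reading in this assay, the data give no sign that a change of this kind moves the number. The step that this estimate means, no change at the digits printed from compound 2 to compound 4 (within the scatter), is expected to be none beyond the scatter. Compound 4 is therefore estimated to give 75000 nM, with a likely range from 35000 nM to 150000 nM.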

Compound 4, half-maximal cytotoxic concentration: 17000 nM
Compound 4: the middle estimate sits 4.4-fold (0.64 log units) above what was measured, outside the stated range (below it).
By their numbers in this assay, from the lowest: compound 4; then compounds 1, 2 and 3 (each within the scatter of the next).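

Placing 4-ethynyl-1,3-thiazol-2-yl instead of 5-isopropyl-1,2-oxazol-3-yl on the aromatic carbon next to the ring nitrogen gives a 4.4-fold lower number from compound 2 to compound 4 (0.64 log units; beyond the scatter) in this assay. The earlier compounds shown here shared a single reading and gave no hint that this position could move the number, but this step shows that the group there can matter, in the direction of higher toxicity in this test. Nothing measured here explains the step.

The compounds shown leave open whether the ethynyl group or the change of ring carries the step, since the two arrive together in one change. They also leave open how an ethyl chain or an amine in place of the ethynyl group would read in this assay.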